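From dimethylamino to (sec-butyl)amino on a carbonyl carbon

The source may hold more compounds than are shown below. What is called first, only, known or untested is meant among the compounds shown, and "the series" means these compounds.

Compound 1 `CCC(O)CNC(=O)/C=C/c1cccc(C(F)(F)F)c1`: 64.4 mg/kg
Compound 2 `CCN1C(=O)CCC1(O)c1cccc(C(F)(F)F)c1`: > 75 mg/kg
Compound 3 `CN(C)C(=O)CCC(=O)c1cccc(C(F)(F)F)c1`: > 37.5 mg/kg

All three compounds were tested in a functional assay on the whole organism with Mus musculus as the target; a higher number here means that more compound is needed for the effect, a lower number that less compound is needed. Only compound 1 gives a true number, 64.4 mg/kg. Compound 2 gives > 75 mg/kg, which is a limit and not a number. Compound 3 gives > 37.5 mg/kg, which is also a limit and not a number. Going by these compounds, the standing of compound 3 therefore stays open, and it cannot be ranked against either of the other two compounds.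

The next compound to be measured is compound 4 `CCC(C)NC(=O)CCC(=O)c1cccc(C(F)(F)F)c1`. It keeps the core of compound 3 and has (sec-butyl)amino in place of dimethylamino on a carbonyl carbon.

Among the compounds with values here, no measured pair here shows what a change of this kind does, so any expectation is a cautious one. Within the data shown here, compound 1, at 64.4 mg/kg, provides the only real number to set the scale. A modest step towards a higher dose is expected in this assay, possibly none beyond the usual scatter, and another result given only as a limit would be no surprise. The estimated change is a step that the limit leaves unreadable from compound 3 to compound 4. For compound 4, the estimated dose is 60 mg/kg, with an expected range from 30 mg/kg to 120 mg/kg.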

Compound 4, dose for half-maximal effect: > 200 mg/kg
Compound 4 gave a limit, no number (the forecaster's own chance of this, stated with the estimate: 40%); at least 3.3-fold (0.52 log units) between middle value and limit.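

In this assay compound 3 gives > 37.5 mg/kg, which is a limit and not a number. Compound 4 gives > 200 mg/kg, which is also a limit, so the step between these two compounds cannot be read. Going by these compounds, what replacing dimethylamino with (sec-butyl)amino does to the dose stays open, as neither compound has a true number.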